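This account rests on a few compounds, and the source may have more. Where it says the series, first, only, none or still open, it means among the compounds named here.

Notes on the series. Compound 3 `COc1ccc(/C=C2\CN(Cc3cn(Cc4ccccc4F)nn3)C/C(=C\c3ccc(OC)cc3)C2=O)cc1` and compound 2 `COc1ccc(/C=C2\CN(Cc3cn(Cc4ccccc4Cl)nn3)C/C(=C\c3ccc(OC)cc3)C2=O)cc1` share a core and differ in one place: chloro in place of fluoro on an aromatic carbon. In a functional assay on DU-145 cells (Homo sapiens) for cytotoxicity, read by MTT assay, with a stated time of 24 h (a lower number here means a stronger inhibitor, a higher number a weaker inhibitor), compound 3 gives 32600 nM and compound 2 gives 17800 nM, so the step of a 1.8-fold lower number from compound 3 to compound 2 (0.26 log units; within the scatter). Compound 1 `Cc1ccc(/C=C2\CN(C(=S)SCc3cn(Cc4ccccc4F)nn3)C/C(=C\c3ccc(C)cc3)C2=O)cc1` has a different core; how it differs from compound 3 is not broken down here. In this assay compound 1 gives 80000 nM, the highest of the three numbers. Compound 4 `Cc1ccc(/C=C2\CN(C(=S)SCc3cn(Cc4ccccc4Cl)nn3)C/C(=C\c3ccc(C)cc3)C2=O)cc1` stands to compound 1 as compound 2 to compound 3: chloro in place of fluoro on an aromatic carbon. The place is described in the same words for both pairs, so the change is taken as the same. The step expected from compound 1 to compound 4 is a 1.8-fold lower number from compound 1 to compound 4 (0.25 log units; within the scatter), resting on the step of a 1.8-fold lower number from compound 3 to compound 2 (0.26 log units; within the scatter), which lies within the scatter. Compound 4 is therefore estimated at 45000 nM, between 20000 nM and 100000 nM.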

Compound 4, half-maximal inhibitory concentration: > 80000 nM
Compound 4: no number, only a limit; the forecaster's own chance of this, stated with the estimate: 15%; middle value at least 1.7-fold (0.24 log units) from the limit.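

For compound 4, the entry > 80000 nM in this assay is a limit of the assay and not a number, so the size of the step from compound 1 cannot be read. The chloro in place of fluoro change gives a number no lower from compound 1 to compound 4 (the limit leaves the size open). The change therefore has no measured size on the core of compound 1 to set beside its size on the core of compound 3: the same change on two cores in this assay, a 1.8-fold lower number (0.26 log units; within the scatter) from compound 3 to compound 2 and a number no lower (the limit leaves the size open) from compound 1 to compound 4; the limit leaves it open whether they differ. This shows neither that the change carries from one core to the other nor that it fails to, and the limit applies to a single value in the set: the limit of > 80000 nM in this assay, at which 1 of the 4 values shown sits.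

The compounds shown leave open how a bromo group on the same aromatic carbon would read on either core. They also leave open whether an amine or a carboxylic acid on that ring would give the core of compound 1 a readable number.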